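The source may report more compounds than this note shows. Statements on the series, on what has been measured and on what is new or still open speak of the compounds shown alone.

Working notes on the series. For the measured compounds named here, compound 1, `CCCCC(C(=O)OC)N1C(=O)/C(=C/c2ccc(C(=O)N[C@@H](CCCNC(=N)N)C(=O)N[C@@H](CCCCN)C(=O)N[C@@H](CCCC)C(N)=O)cc2)SC1=S`, is the only member with a number in hand: in an ADME assay for permeability, using PAMPA (on this read-out higher numbers stand for higher permeability and lower numbers for lower permeability), compound 1 gives 0.87 10^-6 cm/s. Compound 2, `CCCC[C@H](NC(=O)[C@H](CCCN)NC(=O)[C@H](CCCNC(=N)N)NC(=O)c1ccc(/C=C2\SC(=O)N(Cc3ccccc3)C2=O)cc1)C(N)=O`, is the other measured member; in this assay compound 2 is reported as "impermeable" (no number reported), without a number. Going by the values given here, no pair of measured compounds differing in one place is available, so no step size is known from the data themselves.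

Compound 3, `CCCC[C@H](NC(=O)[C@H](CCCCN)NC(=O)[C@H](CCCNC(=N)N)NC(=O)c1ccc(/C=C2\SC(=S)N(c3ccc(OC)cc3)C2=O)cc1)C(N)=O`, is not yet measured. It differs from compound 1 as follows: 4-methoxyphenyl in place of 1-(methoxycarbonyl)pentyl on an amide-type nitrogen in a ring.

With compound 1 already standing low on this assay and compound 2 giving no number at all, the step of a 1.5-fold lower number from compound 1 to compound 3 (0.16 log units; within the scatter) is expected to be small, either none beyond the scatter or slightly downward. The estimate for compound 3 in this assay is 0.6 10^-6 cm/s, with a range from 0.15 10^-6 cm/s to 1.6 10^-6 cm/s, and a real chance that only a limit is reported.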

Compound 3, apparent permeability: 0.59 10^-6 cm/s
Estimate against measurement, compound 3: 1.0-fold (0.01 log units) above, within the range that was stated.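

In this assay, for the compounds shown here, the exchange of 1-(methoxycarbonyl)pentyl for 4-methoxyphenyl on the amide-type nitrogen in the ring gives a 1.5-fold lower number from compound 1 to compound 3 (0.17 log units; within the scatter) and is the first step known. At this position, an open group with no ring and a group with a six-membered aromatic ring of carbon only are therefore not separated by this read-out. No measurement at hand gives a reason for this result or bears on either group's contribution.

On these data alone, whether a carboxylic acid, a primary amine or a longer alkyl chain on this nitrogen would give a step beyond the scatter remains open. Also open, as far as these compounds go, is whether the same exchange would give a similar step with a different side chain on the core of compound 1.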